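Carbamate chain change on a selenium series

The compounds below may be only part of what the source reports. "The series", "measured", "known", "first", "only" and "open" are said of these compounds alone.

Working notes on three measured compounds and one still pending. Compound 1 `CC(C)COC(=O)Nc1ccc([Se][Se]c2ccc(NC(=O)OCC(C)C)cc2)cc1` gives 66.5% in a physicochemical assay, with a stated time of 180 min, tested at 0.5 mg/mL; a higher number here means more inhibition at the concentration tested (going by the name of the read-out), a lower number less inhibition. Compound 3 `CCCCOC(=O)Nc1ccc([Se][Se]c2ccc(NC(=O)OCCCC)cc2)cc1` gives 36.1% in this assay. Compound 2 `N#C[Se]c1ccc(NC(=O)OCc2ccccc2)cc1` gives 3.7% in this assay, the lowest of the three numbers; its gap to compound 3 and its larger gap to compound 1 both lie beyond the scatter. Among the measured compounds shown here, no two measured compounds differ in a single place, so no step between measured compounds can be read off, and the two compounds with two selenium atoms share nothing single with compound 2 that could be isolated.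

Compound 4 `CCOC(=O)Nc1ccc([Se]C#N)cc1` has not yet been measured. It differs from compound 2 as follows: methyl in place of phenyl on a saturated chain carbon bound to an oxygen next to a carbonyl group. Compound 2 stands at 3.7%, and nothing measured shows how this change acts. The expected step is a number 4.3 percentage points higher from compound 2 to compound 4 (within the scatter), no change beyond the scatter in either direction. Compound 4 is expected to give 8%, with a range from 0% to 25%.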

Compound 4, a percentage reported as inhibition, at one concentration (the size of the read-out at that concentration, not a potency): 37%
Estimate against measurement, compound 4: 29 percentage points below; measured number above the stated range.
By their numbers in this assay, from the lowest: compound 2; then compounds 3 and 4 (each within the scatter of the next); then compound 1.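

In this assay, methyl in place of phenyl on a saturated chain carbon bound to an oxygen next to a carbonyl group gives a number 33.3 percentage points higher from compound 2 to compound 4 (beyond the scatter). Among the compounds shown here, this is the first single change read, and it shows that this place alone can move the number beyond the scatter while the rest of compound 2 stays fixed; the phenyl is not required for the higher number, which belongs to the methyl compound. No measurement here bears on why the number moves.

As far as these compounds go, whether a cyclohexyl group or a terminal amine at this place would stand nearer compound 2 or compound 4 remains open. For the compounds shown here, whether the same change would act alike in compounds with two selenium atoms cannot be read, since no single-change pair connects them to compound 2 or compound 4.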